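The source may report more compounds than this note shows. Statements on the series, on what has been measured and on what is new or still open speak of the compounds shown alone.

Compound 1 `CC(C)OC(=O)N1CCC(Oc2cccc3c2CCN3c2ccc(S(C)(=O)=O)cc2F)CC1`: 1000 nM
Compound 2 `CC(C)OC(=O)N1CCC(Oc2ncnc3c2CCN3c2ccc(-c3cccn3C)cc2F)CC1`: 158 nM
Compound 3 `COC(=O)N1CCC(Oc2ncnc3c2CCN3c2ccc(S(C)(=O)=O)cc2F)CC1`: 316 nM

These three compounds were tested in a functional assay on CHO-K1 cells for agonist activity at Glucose-dependent insulinotropic receptor (Homo sapiens), read by a luciferase reporter, with a stated time of 5 h; on this read-out higher numbers stand for an effect only at larger amounts of compound and lower numbers for an effect already at smaller amounts. Among the three numbers, compound 3 holds the second highest. Compound 2 sits nearest to it, and the gap between the two lies within the usual scatter of this assay, so nothing separates them. Compound 1 lies furthest from compound 3, with a higher number, and that gap lies beyond the scatter. Compound 3 and compound 1 also differ in more than one place, so no single change can be tied to that gap.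

Compound 4 `CN(C)S(=O)(=O)N1CCC(Oc2ncnc3c2CCN3c2ccc(S(C)(=O)=O)cc2F)CC1` has not yet been measured. Compared with compound 3 it shows (dimethylsulfamoyl in place of methoxycarbonyl on an amine nitrogen in a ring). The rest of the molecule matches compound 3. For the measured compounds named here, no pair of measured compounds in this set shows the same exchange, so the size of the step cannot be read from the data and must be estimated. In this assay the expected step is a 1.3-fold higher number from compound 3 to compound 4 (0.10 log units; within the scatter), which amounts to no movement beyond the scatter in either direction. Compound 4 is therefore estimated at 400 nM, with a range from 130 nM to 1300 nM.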

Compound 4, half-maximal effective concentration: 398 nM
Estimate against measurement, compound 4: 1.0-fold (0.00 log units) above, within the range that was stated.
By their numbers in this assay, from the lowest: compounds 2, 3 and 4 (each within the scatter of the next, the first and the last beyond it); then compound 1.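

In this assay, for the compounds shown here, the step of a 1.3-fold higher number from compound 3 to compound 4 (0.10 log units; within the scatter) is the first that can be read at this position, the amine nitrogen in a six-membered non-aromatic ring, and it stays within the scatter. The exchange swaps methoxycarbonyl for dimethylsulfamoyl, a group with more heavy atoms that brings in sulfur and nitrogen, while the counts of hydrogen-bond donors and acceptors stay the same and neither group carries a net charge. So in this one pair, replacing the carbonyl-based group with a sulfur-based one leaves the read-out without movement beyond the scatter, and no measurement here gives a reason for that.

No other step among these compounds can be read, since all other pairs differ in more than one place, so this result rests on a single pair and on the core shared by compound 3 and compound 4. From the compounds shown here alone, it remains open whether a group of a different kind on this ring nitrogen, such as a plain methyl, a benzyl or a carboxylic acid on a longer chain, would shift the number beyond the scatter.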